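Two Methyl Groups Added to the Hydroxycyclohexyl Ring

A few compounds are considered here, and "the series" means these few. Any claim that something is new, unique, unknown or untested is made for them only; others in the source may bear on it.

Compound 1 `N#Cc1cnc(NCc2cnccc2C(F)(F)F)cc1N[C@H]1CC[C@H](O)CC1`: 350 nM
Compound 2 `N#Cc1cnc(NCc2cncnc2-c2ccccc2)cc1N[C@H]1CC[C@@H](O)CC1`: 90 nM
Compound 3 `CC1(C)C[C@H](Nc2cc(NCc3cnccc3C(F)(F)F)ncc2C#N)CC(C)(C)[C@@H]1O`: 12 nM

Three compounds built on the shared core of compound 1 have been measured in an assay on isolated protein for inhibition of protein kinase C theta type (Homo sapiens), read by TR-FRET, with a stated time of 2 h; a lower number here means a stronger inhibitor, a higher number a weaker inhibitor. Compound 1 gives 350 nM, the highest number of the three, so it is the weakest inhibitor measured so far. Compound 2 gives 90 nM, and compound 3 gives 12 nM; both gaps to compound 1 lie beyond the usual scatter, and the gap to compound 3 is by far the larger.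

Compound 4 `CC1(C)C[C@H](Nc2cc(NCc3cnccc3C(F)(F)F)ncc2C#N)CC[C@H]1O` has not yet been measured. It differs from compound 1 in one place: 4-hydroxy-3,3-dimethylcyclohexyl in place of 4-hydroxycyclohexyl on a nitrogen on an aromatic ring. Within the data shown here, no directly comparable step between measured compounds is available, so the expectation rests on what the numbers show. Compound 3 carries a ring of the same kind bearing even more methyl groups and gives a far lower number than compound 1, while compound 2 differs elsewhere and is not informative here.

The number for compound 4 is therefore expected to fall in this assay, by a sizeable step an 8.8-fold lower number from compound 1 to compound 4 (0.94 log units; beyond the scatter), because compound 3 with its more heavily methylated ring gives 12 nM. Compound 4 is estimated at 40 nM, with a plausible range from 12 nM to 130 nM.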

Compound 4, half-maximal inhibitory concentration: 100 nM
The estimate for compound 4 lay 2.5-fold (0.40 log units) below the measured number, and the stated range covers the measured number.
By their numbers in this assay, from the lowest: compound 3; then compounds 2 and 4 (each within the scatter of the next); then compound 1.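

In this assay, the change from 4-hydroxycyclohexyl to 4-hydroxy-3,3-dimethylcyclohexyl on a nitrogen on an aromatic ring gives a 3.5-fold lower number from compound 1 to compound 4 (0.54 log units; beyond the scatter), which shows that this position accepts two extra methyl groups and that the inhibitor becomes stronger, not weaker, with them in place. Compound 3, whose ring carries still more methyl groups, gives 12 nM, while compound 4 gives 100 nM, so the dimethyl change accounts for only part of the distance from compound 1 to compound 3. Nothing available here explains why the number falls with this change.

As far as these compounds go, it remains open whether a ring with a single methyl group, or with ethyl groups in place of the methyl groups, would give a similar number, and whether the hydroxyl group itself matters, as an amine in its place would test. From the compounds shown here alone, it is also open whether the same dimethyl change would lower the number on compound 2, which differs from compound 1 in its other substituent on the shared core.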